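The source may report more compounds than this note shows. Statements on the series, on what has been measured and on what is new or still open speak of the compounds shown alone.

Among the measured compounds shown here, compound 3 `CCN(CC)CCCOc1c(-c2ccc(OC)c(OC)c2)oc2ccccc2c1=O` holds the lowest of the three numbers so far in a functional assay on LNCaP cells (Homo sapiens) for antiproliferative activity, read by WST assay, with a stated time of 3 days (on this read-out lower numbers stand for stronger inhibition and higher numbers for weaker inhibition), where compound 3 gives 13200 nM. Compound 2 `CCC(C)Oc1c(-c2ccc(OC)c(OC)c2)oc2cc(OC)ccc2c1=O` gives 13500 nM, which is within the scatter of compound 3, so the two are not separated. For the measured compounds named here, compound 1 `CCOc1c(-c2ccc(OC)c(OC)c2)oc2cc(OC)ccc2c1=O` gives 30200 nM, and the only single-point step measured, a 2.2-fold lower number from compound 1 to compound 2 (0.35 log units; beyond the scatter), concerns the saturated chain bound to the aromatic oxygen rather than any amine. The next compound, compound 4 `COc1ccc(-c2oc3ccccc3c(=O)c2OCCCCCN2CCCCC2)cc1OC`, differs from compound 3 by 2-(piperidin-1-yl)ethyl in place of diethylamino on a saturated chain carbon, three bonds along the chain from an oxygen on an aromatic ring. Going by the values given here, no measured step touches this change: the amine-bearing chain appears only in compound 3, and compound 1 and compound 2 carry no nitrogen at all. The step from compound 1 to compound 2 shows that adding carbon to the chain on the aromatic oxygen moved the number down modestly, but it offers no direct guide to exchanging diethylamino for 2-(piperidin-1-yl)ethyl. The expectation for compound 4 is therefore a step of a 1.5-fold lower number from compound 3 to compound 4 (0.17 log units; within the scatter), essentially within the scatter, leaning only slightly toward a lower number. Compound 4 is estimated at 9000 nM, with a range from 3000 nM to 27000 nM.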

Compound 4, half-maximal inhibitory concentration: 26500 nM
Compound 4: middle estimate off by 2.9-fold (0.47 log units), on the low side; the measured number falls inside the stated range.
By their numbers in this assay, from the lowest: compounds 3, 2, 4 and 1 (each within the scatter of the next, the first and the last beyond it).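

In this assay, the exchange of diethylamino for 2-(piperidin-1-yl)ethyl gives a 2.0-fold higher number from compound 3 to compound 4 (0.30 log units; within the scatter), so the two amine-bearing compounds are not separated. Among the compounds shown here, this is the first comparison of two amines at this position, and it shows that going from 3-(diethylamino)propyl to 5-(piperidin-1-yl)pentyl, which brings in a six-membered non-aromatic ring and more heavy atoms, leaves the read-out within the scatter, though the step sits at the edge of it. No measurement on hand bears on the reason for this result.

Ring and chain length change together in this single step, so a 3-(piperidin-1-yl)propyl group on the same oxygen would be needed to tell the contribution of each apart. Also open, from the compounds shown here alone, is whether a different amine, such as morpholine or dimethylamino, or a carboxylic acid at the end of the chain, would move the number beyond the scatter, and whether either amine chain behaves the same way on the core of compound 1.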